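The source may hold more compounds than are shown below. What is called first, only, known or untested is meant among the compounds shown, and "the series" means these compounds.

Measured so far in the series:

compound 1 `COc1ccc(OC(=O)C#Cc2ccccc2)cc1` — 19100 nM
compound 2 `O=C1C=CC2(C=C1)OC(=O)C(I)=C2c1ccccc1` — 6330 nM
compound 3 `O=C1C=CC2(C=C1)OC(=O)C(c1cc3ccccc3s1)=C2c1ccccc1` — 10800 nM

All three numbers come from an ADME assay on MEpiC cells (Homo sapiens) for antiproliferative activity, read by MTT assay, with a stated time of 48 h; a lower number here means a stronger inhibitor, a higher number a weaker inhibitor. Compound 3 stands second highest of the three. Its nearest neighbour is compound 2: the step from compound 2 to compound 3, a 1.7-fold higher number from compound 2 to compound 3 (0.23 log units; within the scatter), lies within the scatter, so the two cannot be ranked against each other. Among the measured compounds shown here, compound 1 is the furthest of the three from compound 3, yet the gap between them is also within the scatter; nothing among the measured compounds separates itself clearly from the rest.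

Compound 4 `O=C1C=CC2(C=C1)OC(=O)C(c1cc3ccccc3o1)=C2c1ccccc1` is the next point. It differs from compound 3 only in that (1-benzofuran-2-yl in place of 1-benzothiophen-2-yl on a double-bonded ring carbon). For the measured compounds named here, no measured pair sets a benzofuranyl against a benzothiophenyl at this position, so there is no step that speaks directly to the exchange. Going by the values given here, the one step that touches this carbon, a 1.7-fold higher number from compound 2 to compound 3 (0.23 log units; within the scatter), replaced iodo by the much larger benzothiophenyl and still stayed within the scatter, which gives no reason to expect that a sulfur-for-oxygen swap within the same bicyclic group should move the number further. The expected step is therefore a 1.1-fold lower number from compound 3 to compound 4 (0.03 log units; within the scatter), none beyond the scatter. Compound 4 is accordingly estimated at 10000 nM, with a range from 4000 nM to 25000 nM.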

Compound 4, half-maximal inhibitory concentration: 66600 nM
The estimate for compound 4 lay 6.7-fold (0.82 log units) below the measured number, outside the stated range (above it).
By their numbers in this assay, from the lowest: compounds 2, 3 and 1 (each within the scatter of the next, the first and the last beyond it); then compound 4.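

In this assay the exchange of 1-benzothiophen-2-yl for 1-benzofuran-2-yl on the double-bonded ring carbon gives a 6.2-fold higher number from compound 3 to compound 4 (0.79 log units; beyond the scatter) and so separates two groups with the same ring types, which differ in the hetero atom of the five-membered aromatic ring. Iodo and 1-benzothiophen-2-yl could not be ranked at this carbon, with a 1.7-fold higher number from compound 2 to compound 3 (0.23 log units; within the scatter), but the change from iodo to 1-benzofuran-2-yl gives an 11-fold higher number from compound 2 to compound 4 (1.02 log units; beyond the scatter) and places compound 4 clearly apart from both; among these three compounds, then, a bicyclic aromatic group at this position does not by itself fix the number, and the choice between sulfur and oxygen in that group matters. Nothing available accounts for this difference.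

From the compounds shown here alone, whether the same gap between oxygen and sulfur would hold with another group in place of the phenyl on the neighbouring-numbered part of the core stays open. Also open, going by these compounds, is where a group of a different kind on the double-bonded ring carbon, such as an amine or a carboxylic acid, would fall relative to compound 2 and compound 4.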